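From an ether chain back to a sulfonyl group

The source may report more compounds than this note shows. Statements on the series, on what has been measured and on what is new or still open speak of the compounds shown alone.

Three compounds sharing one core were measured in an ADME assay on microsomes from liver (Homo sapiens) for metabolic stability, read by LC-MS, tested at 1 uM; on this read-out higher numbers stand for fast clearance and lower numbers for slow clearance. Compound 1 `O=S(=O)(c1ccc([C@H]2CC[C@]3(CC2)OOC2(O3)C3CC4CC(C3)CC2C4)cc1)N1CCNCC1` gives 16 mL.min-1.g-1 in this assay. Compound 2 `c1cc([C@H]2CC[C@]3(CC2)OOC2(O3)C3CC4CC(C3)CC2C4)ccc1OCCCNC1CCOCC1` gives 10 mL.min-1.g-1 in this assay. Compound 3 `c1cc([C@H]2CC[C@]3(CC2)OOC2(O3)C3CC4CC(C3)CC2C4)ccc1OCCOC1CCNCC1` reaches the limit of < 7 mL.min-1.g-1 in this assay, at which 1 of the 3 values shown sits, in this assay, so its reading of < 7 mL.min-1.g-1 is a limit rather than a number.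

Compound 4 `NC1CCN(S(=O)(=O)c2ccc([C@H]3CC[C@]4(CC3)OOC3(O4)C4CC5CC(C4)CC3C5)cc2)CC1` differs from compound 3 by (4-aminopiperidin-1-yl)sulfonyl in place of 2-((piperidin-4-yl)oxy)ethoxy on an aromatic carbon. The measured step that bears most directly on this change runs the other way: an at least 2.2-fold lower number from compound 1 to compound 3 (0.35 log units; beyond the scatter). By comparison, a 1.6-fold lower number from compound 1 to compound 2 (0.20 log units; within the scatter). Since compound 4 carries a sulfonyl group on the same aromatic carbon as compound 1 does, a return toward the reading of compound 1 is expected, namely an at least 2.0-fold higher number from compound 3 to compound 4 (0.30 log units; that floor lies within the scatter). Compound 4 is therefore estimated at 14 mL.min-1.g-1, with a range from 7 mL.min-1.g-1 to 30 mL.min-1.g-1.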

Compound 4, intrinsic clearance in microsomes: < 7 mL.min-1.g-1
Compound 4: only a limit was reported; the forecaster's own chance of this, stated with the estimate: 20%; middle value at least 2.0-fold (0.30 log units) away from the limit.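

On the sulfonyl sulfur, 4-aminopiperidin-1-yl in place of piperazin-1-yl gives an at least 2.2-fold lower number from compound 1 to compound 4 (0.35 log units; beyond the scatter) in this assay, so a sulfonyl group on this aromatic carbon does not by itself bring back the reading of compound 1. Set against the propoxy chain, the same group gives an at least 1.4-fold lower number from compound 2 to compound 4 (0.15 log units; that floor lies within the scatter), while the step between compound 3 and compound 4 cannot be read. The reading of compound 4 is a limit, not a number: the limit of < 7 mL.min-1.g-1 in this assay, at which 2 of the 4 values shown sit.

Going by these compounds, how far compound 3 and compound 4 lie past that limit stays open. Also open, on these data alone, is whether a morpholine on the sulfonyl sulfur would stay at the limit or sit nearer compound 1.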